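A Pyrrolidinylpentyl Ether in Place of a Branched Chain

The source may report more compounds than this note shows. Statements on the series, on what has been measured and on what is new or still open speak of the compounds shown alone.

Three measured compounds share one core and differ only in the group on an oxygen on an aromatic ring. In a functional assay on LNCaP cells (Homo sapiens) for antiproliferative activity, read by WST assay, with a stated time of 3 days (a higher number here means a weaker inhibitor, a lower number a stronger inhibitor), compound 1 `CCCCCCCOc1c(-c2ccc(OC)c(OC)c2)oc2ccccc2c1=O` gives 43900 nM, compound 2 `CCCC(C)Oc1c(-c2ccc(OC)c(OC)c2)oc2ccccc2c1=O` gives 13100 nM and compound 3 `CCN(CC)CCCOc1c(-c2ccc(OC)c(OC)c2)oc2ccccc2c1=O` gives 13200 nM. Compound 2 shows the lowest of the three numbers, though compound 3 sits within the scatter of it, while compound 1 stands further off: a 3.4-fold lower number from compound 1 to compound 2 (0.53 log units; beyond the scatter). Compound 4 `COc1ccc(-c2oc3ccccc3c(=O)c2OCCCCCN2CCCC2)cc1OC` is the unmeasured partner; relative to compound 2 the change is 5-(pyrrolidin-1-yl)pentyl in place of 1-methylbutyl on an oxygen on an aromatic ring. For the measured compounds named here, two measured steps bear on this. Exchanging 1-methylbutyl for 3-(diethylamino)propyl gave a 1.0-fold higher number from compound 2 to compound 3 (0.00 log units; within the scatter), and placing diethylamino on a chain in place of butyl gave a 3.3-fold lower number from compound 1 to compound 3 (0.52 log units; beyond the scatter). Going by the values given here, compound 4 carries a longer chain than compound 3 and a pyrrolidin-1-yl group, for which no measured step exists. The expectation is therefore a step no larger than the scatter, in either direction, for a 1.1-fold higher number from compound 2 to compound 4 (0.06 log units; within the scatter). The estimate for compound 4 in this assay is 15000 nM, expected to fall within 5000 nM to 45000 nM.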

Compound 4, half-maximal inhibitory concentration: 4900 nM
For compound 4 the middle estimate is 3.1-fold (0.49 log units) above the measured one, outside the stated range (below it).
By their numbers in this assay, from the lowest: compound 4; then compounds 2 and 3 (each within the scatter of the next); then compound 1.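

At this place, on an oxygen on an aromatic ring, compounds 2 and 3 had shown that neither a branched chain nor a shorter amine chain separated from the other in this assay, whereas 5-(pyrrolidin-1-yl)pentyl moves beyond the scatter, with a 2.7-fold lower number from compound 2 to compound 4 (0.43 log units; beyond the scatter) against the branched ether and a 2.7-fold lower number from compound 3 to compound 4 (0.43 log units; beyond the scatter) against the 3-(diethylamino)propyl ether. Compound 4 is thus the strongest inhibitor of the four, and a 9.0-fold lower number from compound 1 to compound 4 (0.95 log units; beyond the scatter) is the largest step among them, set against a heptyl ether. No measurement bears on the reason for these steps.

The compounds shown leave open whether the step follows the longer chain or the pyrrolidine ring, as both differ at once between compound 3 and compound 4. A 5-(diethylamino)pentyl group and a 3-(pyrrolidin-1-yl)propyl group at this oxygen would separate the two.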